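This account rests on a few compounds, and the source may have more. Where it says the series, first, only, none or still open, it means among the compounds named here.

Compound 2 `Cc1nc(-c2ccccc2)sc1C(=O)CSc1nc(-c2ccc(Cl)c(Cl)c2)c(C#N)c(=O)[nH]1` and compound 1 `COc1ccc(-c2nc(SCC(=O)c3sc(-c4ccccc4)nc3C)[nH]c(=O)c2C#N)cc1` share a common core and differ only in the aryl group attached to it. Among the compounds with values here, in a functional assay on U-87MG ATCC cells for antiproliferative activity against U-87 MG (Homo sapiens), read by MTT assay, with a stated time of 48 h, tested at 5 uM (a lower number here means a stronger effect, a higher number a weaker effect of the compound at the concentration tested), compound 2 gives 98.6%, and compound 1 gives 97.3%, a number that lies within the scatter of that of compound 2; the only measured step, a number 1.3 percentage points higher from compound 1 to compound 2 (within the scatter), therefore shows no effect beyond the scatter. Compound 3 `Cc1nc(-c2ccccc2)sc1C(=O)CSc1nc(-c2ccc(Cl)cc2)c(C#N)c(=O)[nH]1` is reached from compound 2 by a single change, (hydrogen in place of chloro on an aromatic carbon). Within the data shown here, no measured step removes a chloro group, so the only guide is that exchanging the whole aryl group between compound 1 and compound 2 left the read-out within the scatter; a smaller change at the same ring is expected to do no more. The step of a number 1.6 percentage points lower from compound 2 to compound 3 (within the scatter) is thus estimated to stay within the scatter. For compound 3 the expected value is 97%, with a range from 88% to 100%.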

Compound 3, a percentage reported as activity, at one concentration (the size of the read-out at that concentration, not a potency): 90.9%
For compound 3 the middle estimate is 6.1 percentage points above the measured one; the range from low to high includes it.
By their numbers in this assay, from the lowest: compounds 3, 1 and 2 (each within the scatter of the next).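

The 3,4-dichlorophenyl to 4-chlorophenyl exchange isolates a single chloro group on this ring: in this assay, hydrogen in place of the chloro group that stands ortho to the remaining chloro group gives a number 7.7 percentage points lower from compound 2 to compound 3 (within the scatter), so losing this one atom has no effect beyond the scatter. Chloro in place of methoxy on the same ring, a number 6.4 percentage points lower from compound 1 to compound 3 (within the scatter), also stays within the scatter, so the aryl groups of compound 1, compound 2 and compound 3 cannot be told apart in this read-out at the single concentration tested. No measurement at hand offers an explanation for this result. Going by these compounds, it remains open whether an amine or a carboxylic acid on this ring would move the read-out beyond the scatter. The compounds shown also leave open whether changes elsewhere on the shared core would do so.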